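The source may report more compounds than this note shows. Statements on the series, on what has been measured and on what is new or still open speak of the compounds shown alone.

Measured compounds:

Compound 1 `O=C1C[C@H](OCc2cn(-c3ccc(F)cc3)nn2)[C@H]2CO[C@@H]1O2`: in a functional assay on MDA-MB-231 cells (Homo sapiens) for cytotoxicity, read by MTT assay, with a stated time of 48 h (a lower number here means a stronger inhibitor, a higher number a weaker inhibitor), compound 1 gives 23700 nM.
Compound 2 `O=C1C[C@H](OCc2cn(-c3ccccc3Br)nn2)[C@H]2CO[C@@H]1O2`: in this assay compound 2 gives 22500 nM.

Among the compounds with values here, compound 2 holds the lower of the two measured numbers, but its only neighbour is compound 1, and the step of a 1.1-fold lower number from compound 1 to compound 2 (0.02 log units; within the scatter) lies within the scatter, so the two compounds cannot be told apart on these data.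

Compound 3 `O=C1C[C@H](OCc2cn(C3CCCCC3)nn2)[C@H]2CO[C@@H]1O2` differs from compound 2 in one place: cyclohexyl in place of 2-bromophenyl on an aromatic nitrogen. Within the data shown here, the one measured step, from compound 1 to compound 2, exchanged one aromatic ring for another on the same nitrogen and changed nothing beyond the scatter. Among the measured compounds shown here, no measured step exchanges an aromatic ring for a non-aromatic one, so the expectation rests only on that small step and on compound 2 itself.

Compound 3 is therefore expected to give a number close to that of compound 2, a step of a 1.1-fold higher number from compound 2 to compound 3 (0.05 log units; within the scatter) that is not expected to exceed the scatter. The estimate for compound 3 in this assay is 25000 nM, with a range from 9000 nM to 70000 nM.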

Compound 3, half-maximal inhibitory concentration: 24300 nM
The estimate for compound 3 lay 1.0-fold (0.01 log units) above the measured number; the range from low to high includes it.
By their numbers in this assay, from the lowest: compounds 2, 1 and 3 (each within the scatter of the next).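

In this assay, cyclohexyl in place of 2-bromophenyl on the aromatic nitrogen gives a 1.1-fold higher number from compound 2 to compound 3 (0.03 log units; within the scatter) and cyclohexyl in place of 4-fluorophenyl gives a 1.0-fold higher number from compound 1 to compound 3 (0.01 log units; within the scatter) on the same nitrogen. Within the data shown here, this is the first non-aromatic ring at this position, and the three compounds still cannot be told apart, so among them neither an aromatic ring on this nitrogen nor a bromine or fluorine on that ring is needed for a number of this size. Nothing measured here bears on why these numbers lie so close together.

The compounds shown leave open whether any group on this nitrogen can move the number beyond the scatter. On these data alone, an amine, a carboxylic acid, a methyl or a longer alkyl chain in this place would test that, and the shared core itself remains unexplored.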